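Adding one carbon to an alkoxy chain on an indole-type core

The source may hold more compounds than are shown below. What is called first, only, known or untested is meant among the compounds shown, and "the series" means these compounds.

Measured compounds:
- compound 1, `CCOc1ccc2[nH]c(-c3ccccc3)c(C3=C(Br)C(=O)NC3=O)c2c1`: 2.77
- compound 2, `CCCOc1ccc2[nH]c(-c3ccccc3)c(C3=C(Br)C(=O)NC3=O)c2c1`: 3.16
- compound 3, `CCCCCOc1ccc2[nH]c(-c3ccc(OC)cc3)c(C3=C(Br)C(=O)NC3=O)c2c1`: 3.77

The three measured compounds were all examined in a physicochemical assay for lipophilicity; on this read-out higher numbers stand for higher lipophilicity and lower numbers for lower lipophilicity. Compound 1 and compound 2 share the same core and differ only by methyl in place of hydrogen on a saturated chain carbon, two bonds along the chain from an oxygen on an aromatic ring. That change gives a number 0.39 log units higher from compound 1 to compound 2 (beyond the scatter). Compound 3 carries a different core; how its core differs from that of compound 1 is not broken down here. In this assay compound 3 stands highest of the three, with both other values well below it.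

Compound 4, `CCCCCCOc1ccc2[nH]c(-c3ccc(OC)cc3)c(C3=C(Br)C(=O)NC3=O)c2c1`, has not yet been measured. It differs from compound 3 by methyl in place of hydrogen on a saturated chain carbon, five bonds along the chain from an oxygen on an aromatic ring. Among the measured compounds shown here, this is the same kind of change as the one from compound 1 to compound 2, though the place differs: there the new methyl sits two bonds along the chain from an oxygen on an aromatic ring, here it sits five bonds along the chain from an oxygen on an aromatic ring.

For compound 4 the step is expected to be about a number 0.43 log units higher from compound 3 to compound 4 (beyond the scatter), resting on the earlier step of a number 0.39 log units higher from compound 1 to compound 2 (beyond the scatter) and on the idea that one more chain carbon usually adds a similar amount in this assay. Compound 4 is therefore estimated at 4.2, with a plausible range from 3.9 to 4.55.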

Compound 4, partition coefficient: 4.1
Beside the measured number, compound 4's estimate is 0.10 log units above it; low and high end bracket the measured number.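

In this assay, the same change, methyl in place of hydrogen on a saturated chain carbon, gives a number 0.39 log units higher from compound 1 to compound 2 (beyond the scatter) when the carbon sits two bonds along the chain from an oxygen on an aromatic ring, and a number 0.33 log units higher from compound 3 to compound 4 (beyond the scatter) when it sits five bonds along. The change therefore moves the number the same way on both cores, and both steps are beyond the scatter, so for these two pairs it carried over from one core to the other in direction. Among the compounds shown here, it does not show that this would hold on any further core, and with only two pairs, which differ in both core and place along the chain, the contribution of each cannot be separated; nothing available here explains either step.

The compounds shown leave open whether the same kind of step would continue with a longer chain than that of compound 4. They also leave open what this assay would give if the chain ended in an amine or a carboxylic acid instead of a methyl group.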